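The source may report more compounds than this note shows. Statements on the series, on what has been measured and on what is new or still open speak of the compounds shown alone.

Measured compounds in an ADME assay on Vero cells (Chlorocebus sabaeus) for cytotoxicity; on this read-out lower numbers stand for higher toxicity in this test and higher numbers for lower toxicity in this test:
compound 1, `O=[N+]([O-])c1ccc(-c2nc3cc(C(F)(F)F)ccc3n2C2CCCCC2)cc1`, > 100000 nM
compound 2, `CCN(CC)CC(=O)Nc1ccc(-c2nc3cc(C(F)(F)F)ccc3[nH]2)cc1`, 24000 nM

Among the measured compounds shown here, compound 2 is the only compound with a number in this assay; the other value shown is a limit. Compound 1 sits at the limit of this assay, (the limit of > 100000 nM in this assay, at which 1 of the 2 values shown sits). Compound 3, `O=[N+]([O-])c1ccc(-c2nc3cc(C(F)(F)F)ccc3[nH]2)cc1`, has not been measured. It differs from compound 2 in one place: nitro in place of (((diethylamino)methyl)carbonyl)amino on an aromatic carbon. For the measured compounds named here, no step between two measured compounds is available, so the size of this change in this assay cannot be read from a measured pair. Compound 1 carries the same nitro group and sits at the limit of this assay. Compound 2 gives 24000 nM. Compound 3 is therefore expected to move toward that limit, a step upward beyond the usual scatter, a 2.5-fold higher number from compound 2 to compound 3 (0.40 log units; beyond the scatter). For compound 3 the estimate in this assay is 60000 nM, with a range from 20000 nM to 150000 nM.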

Compound 3, half-maximal cytotoxic concentration: 45000 nM
Compound 3: middle estimate off by 1.3-fold (0.12 log units), on the high side; the measured number falls inside the stated range.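

In this assay, nitro in place of (((diethylamino)methyl)carbonyl)amino on an aromatic carbon gives a 1.9-fold higher number from compound 2 to compound 3 (0.27 log units; within the scatter), so at this position the two groups cannot be told apart, despite the difference in size between them. Among the compounds shown here, the readable step lies instead on the aromatic nitrogen, where hydrogen in place of cyclohexyl gives an at least 2.2-fold lower number from compound 1 to compound 3 (0.34 log units; beyond the scatter), and this is the first step beyond the usual scatter. The value of compound 1 is a limit, so the full size of that step stays unknown: the limit of > 100000 nM in this assay, at which 1 of the 3 values shown sits.

Going by these compounds, whether an amine or a carboxylic acid on the same aromatic carbon would stay in the range of compound 2 and compound 3 remains open. So does the response on the aromatic nitrogen to a group smaller than cyclohexyl, such as methyl or ethyl.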